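The source may report more compounds than this note shows. Statements on the series, on what has been measured and on what is new or still open speak of the compounds shown alone.

In an ADME assay on MT4 cells (Homo sapiens) for activation, read by MTT assay (a lower number here means that less compound is tolerated, a higher number that more compound is tolerated), compound 1 (`CCC(C)Sc1nc(C(CC)c2c(F)cccc2Cl)c(C)c(=O)[nH]1`) gives > 3000 nM as a limit and not a number. Compound 2 (`CCC(c1nc(SC2CCCC2)[nH]c(=O)c1C)c1c(F)cccc1Cl`) gives > 3000 nM as a limit too. The position of compound 1 is thus known only as the limit of > 3000 nM in this assay, at which 2 of the 2 values shown sit, and nothing finer. Compound 3 (`CCC(C)Sc1nc(C(CC)c2c(F)cccc2F)c(C)c(=O)[nH]1`) differs from compound 1 by one exchange (fluoro in place of chloro on an aromatic carbon) with fluoro in place of chloro on an aromatic carbon, ortho to a large group and meta to a fluoro group, so that 2-chloro-6-fluorophenyl becomes 2,6-difluorophenyl. Within the data shown here, the only measured step is a step that the two limits leave unreadable from compound 1 to compound 2 with cyclopentyl in place of sec-butyl on a sulfur, at another place, and it gives no size to carry over. No step beyond the usual scatter is therefore expected in this assay and no direction can be assigned. The expected move is a step that the limit leaves unreadable from compound 1 to compound 3 as an estimate only. Compound 3 is estimated at 6000 nM with an expected range from 3000 nM to 40000 nM and may well turn out to be only a limit.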

Compound 3, half-maximal cytotoxic concentration: > 3000 nM
Compound 3 was reported as a limit; the forecaster's own chance of this, stated with the estimate: 80%; the middle value is on the limit's open side.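

In this assay, among these compounds, compound 3 gives > 3000 nM, a limit and not a number; compound 1 is also reported as a limit, so no step between compound 1 and compound 3 can be read. The compounds shown leave open where each true value lies and whether either exchange changes it: the limit of > 3000 nM in this assay, at which 3 of the 3 values shown sit.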